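This account rests on a few compounds, and the source may have more. Where it says the series, first, only, none or still open, it means among the compounds named here.

In a functional assay on HepG2 cells (Homo sapiens) for cytotoxicity, read by MTT assay, with a stated time of 24 h (on this read-out lower numbers stand for stronger inhibition and higher numbers for weaker inhibition), compound 1 `CN1C/C(=C\c2cccnc2)C(=O)/C(=C/c2ccccc2F)C1` gives 4810 nM and compound 2 `O=C1/C(=C/c2cccnc2)CN(S(=O)(=O)c2ccc(C(F)(F)F)cc2)C/C1=C\c1ccccc1F` gives 2400 nM. These two numbers lie within the usual scatter of each other, so compound 2 stands level with compound 1. Compound 3 `O=C1/C(=C/c2cccnc2)CN(S(=O)(=O)c2ccc(F)cc2)C/C1=C\c1ccccc1F` matches compound 2 except at one place: fluoro in place of trifluoromethyl on an aromatic carbon. For the measured compounds named here, no measured pair shows this change, so no shift beyond the scatter is expected. The expected step is a 1.0-fold higher number from compound 2 to compound 3 (0.02 log units; within the scatter). For compound 3 the estimated value is 2500 nM, with an expected range of 1000 nM to 6000 nM.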

Compound 3, half-maximal inhibitory concentration: 15600 nM
For compound 3 the middle estimate is 6.2-fold (0.80 log units) below the measured one; measured number above the stated range.
By their numbers in this assay, from the lowest: compounds 2 and 1 (each within the scatter of the next); then compound 3.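

In this assay, changing 4-(trifluoromethyl)phenyl to 4-fluorophenyl gives a 6.5-fold higher number from compound 2 to compound 3 (0.81 log units; beyond the scatter) and thus shows that this single aromatic position affects the read-out. Placing (4-fluorophenyl)sulfonyl instead of methyl on the ring amine nitrogen gives a 3.2-fold higher number from compound 1 to compound 3 (0.51 log units; beyond the scatter) and so does not keep the level of compound 1, whereas compound 2, with its trifluoromethyl group, stands level with compound 1. No measurement shown here explains this shift.

Going by these compounds, it remains open whether a chloro, methoxy or amino group at this position would give a number closer to compound 2 or to compound 3. On these data alone, it is also open whether the same change would give a similar step on a different core.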